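Methoxy placement in a small cytotoxicity series

This account rests on a few compounds, and the source may have more. Where it says the series, first, only, none or still open, it means among the compounds named here.

Values in a functional assay on A549 cells (Homo sapiens) for cytotoxicity, read by MTT assay, with a stated time of 72 h; a lower number here means a stronger inhibitor, a higher number a weaker inhibitor:
compound 1 `COc1ccc(/C=C2\CCC/C(=C\c3cccc(OC)c3OC)C2=O)cc1` gives > 20000 nM, a limit of the assay and not a number.
compound 2 `COc1ccc(/C=C2\CCC/C(=C\c3cccc(OC)c3OC)C2=O)c(OC)c1` gives > 20000 nM, also a limit.
compound 3 `COc1cccc(/C=C2\CCC/C(=C\c3ccc(OC)c(OC)c3)C2=O)c1` gives 6700 nM.

Compound 1 and compound 3 have the same atoms joined differently; the difference between the two cores is not broken down here. From compound 1 to compound 2 the change is methoxy in place of hydrogen on an aromatic carbon; the resulting step that the two limits leave unreadable from compound 1 to compound 2 cannot be sized because of the limit of > 20000 nM in this assay, at which 2 of the 3 values shown sit. Compound 4 `COc1cc(/C=C2\CCC/C(=C\c3ccc(OC)c(OC)c3)C2=O)cc(OC)c1` is not yet measured and differs from compound 3 by methoxy in place of hydrogen on an aromatic carbon, the same kind of change, though the place is meta to a large group rather than ortho to it. Since the measured example gives no size, the expectation for compound 4 rests on compound 3 alone, anchored at 6700 nM. Compound 4 is expected near 8000 nM, between 2500 nM and 20000 nM, an expected step of a 1.2-fold higher number from compound 3 to compound 4 (0.08 log units; within the scatter).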

Compound 4, half-maximal inhibitory concentration: 5100 nM
Estimate against measurement, compound 4: 1.6-fold (0.20 log units) above; measured number inside the range.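

In this assay, adding the methoxy to the core of compound 3 gives a 1.3-fold lower number from compound 3 to compound 4 (0.12 log units; within the scatter), so on this core the change leaves no difference that can be told from scatter. The same change cannot be read on the core of compound 1, because compound 1 and compound 2 both stand at a limit of the assay and not a number: the limit of > 20000 nM in this assay, at which 2 of the 4 values shown sit.

The series therefore holds a single readable step, which does not show that the change carries over from one core to the other. The compounds shown leave open whether a group other than methoxy on the same aromatic carbon, such as an amine or a carboxylic acid, would give a step beyond the scatter in this assay. Also open, going by these compounds, is how the core of compound 1 responds to any change, since its values give no number.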